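The compounds below may be only part of what the source reports. "The series", "measured", "known", "first", "only" and "open" are said of these compounds alone.

Compound 1 `CCCS(=O)(=O)Nc1cccc2c1CCC2c1ncc[nH]1` gives 54% in a functional assay on CHO cells for agonist activity at Alpha-1A adrenergic receptor (Homo sapiens), read by FLIPR and calcium flux (a lower number here means a smaller maximal response, a higher number a larger maximal response), the higher of the two measured values; its closest measured neighbour is compound 2 `Cn1ccc(-c2cccc3c2CCC3c2ncc[nH]2)n1`, and compound 2 gives 19%. That step, a number 35 percentage points lower from compound 1 to compound 2 (beyond the scatter), replaced the same (propylsulfonyl)amino with a five-membered aromatic ring, so it bears directly on compound 3 `Cc1oncc1-c1cccc2c1CCC2c1ncc[nH]1`, which changes compound 1 by 5-methyl-1,2-oxazol-4-yl in place of (propylsulfonyl)amino on an aromatic carbon. Because the earlier step of a number 35 percentage points lower from compound 1 to compound 2 (beyond the scatter) was large and downward, a drop of similar size is expected here, namely a number 29 percentage points lower from compound 1 to compound 3 (beyond the scatter). Compound 3 is therefore estimated to give 25% in this assay, within a range from 10% to 45%.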

Compound 3, largest response reached (Emax), in percent of the reference or control that the assay uses: 63%
Beside the measured number, compound 3's estimate is 38 percentage points below it, and the stated range ends below it.
By their numbers in this assay, from the lowest: compound 2; then compounds 1 and 3 (each within the scatter of the next).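

A five-membered aromatic ring at this position need not lower the response: in this assay, 5-methyl-1,2-oxazol-4-yl in place of (propylsulfonyl)amino gives a number 9 percentage points higher from compound 1 to compound 3 (within the scatter) and so keeps the response of the sulfonamide-bearing compound. The choice of ring matters, since exchanging 1-methyl-1H-pyrazol-3-yl for 5-methyl-1,2-oxazol-4-yl gives a number 44 percentage points higher from compound 2 to compound 3 (beyond the scatter) on the same core. Nothing measured here explains that gap between the two rings. Still open, going by these compounds, is how a six-membered ring such as pyridine, or a simple amine, would behave at this position.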